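Swapping the imidazole back for a lactam-bearing chain

The source may report more compounds than this note shows. Statements on the series, on what has been measured and on what is new or still open speak of the compounds shown alone.

Compound 2 `Cc1c[nH]c(C(c2ccc(-c3ccc4cccc(F)c4c3)[nH]c2=O)C(C)C)n1` has the highest number of the two measured in a functional assay on CHO cells for antagonist activity at prostaglandin E2 receptor EP3 subtype (Homo sapiens), read by cAMP accumulation; a lower number here means a stronger inhibitor, a higher number a weaker inhibitor: compound 2 gives 36 nM, while compound 1 `CC(C)C(/C=C1/CCNC1=O)c1ccc(-c2ccc3cccc(F)c3c2)[nH]c1=O` gives 8.1 nM. Compound 3 `CC(C)C(/C=C1\CCNC1=O)c1ccc(-c2ccc3cccc(F)c3c2)[nH]c1=O` differs from compound 2 by a group of 7 heavy atoms (5 carbon, 1 nitrogen, 1 oxygen; one five-membered non-aromatic ring with 1 hetero atom) in place of a group of 6 heavy atoms (4 carbon, 2 nitrogen; one five-membered aromatic ring with 2 hetero atoms), on a saturated chain carbon bound to an aromatic carbon and a saturated chain carbon. For the measured compounds named here, the one step that bears on this change runs the other way: a 4.4-fold higher number from compound 1 to compound 2 (0.65 log units; beyond the scatter). Reversing it, compound 3 is expected to show a lower number, with a 3.0-fold lower number from compound 2 to compound 3 (0.48 log units; beyond the scatter) as the estimated step. Compound 3 is therefore estimated at 12 nM, within a range of 3 nM to 50 nM.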

Compound 3, half-maximal inhibitory concentration: 8.7 nM
Beside the measured number, compound 3's estimate is 1.4-fold (0.14 log units) above it; the range from low to high includes it.
By their numbers in this assay, from the lowest: compounds 1 and 3 (each within the scatter of the next); then compound 2.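

The lactam-bearing chain brings back the lower number with its double bond drawn either way, with a 4.1-fold lower number from compound 2 to compound 3 (0.62 log units; beyond the scatter). Changing that double bond from Z to E makes no difference that can be told apart, with a 1.1-fold higher number from compound 1 to compound 3 (0.03 log units; within the scatter), so this position shows no preference between the two drawn forms. One caution applies to that comparison: the fact that one of compounds 1 and 3 is drawn with a defined configuration and the other without, at the place where they differ

The compounds shown leave open whether the ring or the double bond matters for the number. An open-chain amide, or a six-membered lactam at the same place, would test this.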